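Chalcone series: ring size of the ether side chain

The compounds below may be only part of what the source reports. "The series", "measured", "known", "first", "only" and "open" are said of these compounds alone.

Working notes on a small set sharing one core. Compound 2 `O=C(/C=C/c1ccc(O)cc1)c1c(O)cccc1OCCC1CCCC1` is the reference point. In a functional assay on NCI-H23 cells (Homo sapiens) for antiproliferative activity, read by sulforhodamine B assay (a higher number here means a weaker inhibitor of growth, a lower number a stronger inhibitor of growth), compound 2 gives 3370 nM, the lowest of the two numbers at hand. Compound 3 `CC(C)(C)CCOc1cccc(O)c1C(=O)/C=C/c1ccc(C(=O)O)cc1` is nearest; in this assay compound 3 gives 4770 nM, a gap from compound 2 that stays within the usual scatter, so no order between the two is claimed. Among the measured compounds shown here, compound 1 `COc1cccc(OCCC(C)(C)C)c1C(=O)/C=C/c1ccc(O)cc1` reports only a limit in this assay, > 30000 nM, not a number; this is the one value sitting at the limit of > 30000 nM in this assay, at which 1 of the 3 values shown sits.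

The next compound, compound 4 `O=C(/C=C/c1ccc(O)cc1)c1c(O)cccc1OCCC1CCCCC1`, differs from compound 2 in one place: cyclohexyl in place of cyclopentyl on a saturated chain carbon, two bonds along the chain from an oxygen on an aromatic ring. For the measured compounds named here, no measured pair in the set shows what this kind of change does, so no size can be read from the data. The expectation is a step of no more than the scatter in either direction, and compound 4 is estimated at 3000 nM, with a range from 1000 nM to 10000 nM. The expected move from compound 2 is a 1.1-fold lower number from compound 2 to compound 4 (0.05 log units; within the scatter), anchored to the value of compound 2, 3370 nM.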

Compound 4, concentration for 50% growth inhibition: > 30000 nM
Compound 4 was reported as a limit (the forecaster's own chance of this, stated with the estimate: 5%); middle value at least 10-fold (1.00 log units) away from the limit.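

Cyclohexyl in place of cyclopentyl on a saturated chain carbon, two bonds along the chain from an oxygen on an aromatic ring, is the first change in the set with a readable size: in this assay it gives an at least 8.9-fold higher number from compound 2 to compound 4 (0.94 log units; beyond the scatter). The end of this side chain is therefore not indifferent to ring size, although neither ring carries a hydrogen-bond donor, an acceptor or a net charge. The reading for compound 4 is a limit and not a number, so the full size of the step stays unread: the limit of > 30000 nM in this assay, at which 2 of the 4 values shown sit.

The compounds shown leave open whether a cyclobutyl ring, an open pentyl chain or a piperidine ring at this place would stay level with compound 2. Equally open, going by these compounds, is how cyclohexyl behaves on a shorter link, as cyclohexylmethoxy on the shared core.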